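This account rests on a few compounds, and the source may have more. Where it says the series, first, only, none or still open, it means among the compounds named here.

Compounds measured so far:

compound 1 `O=C1c2ccc(C#Cc3cccnc3)nc2CCN1C1CCCC1` — in an assay on HEK293 cells for displacement of a labelled ligand from metabotropic glutamate receptor 5 (Homo sapiens), with a stated time of 2 h (a lower number here means a stronger inhibitor, a higher number a weaker inhibitor), compound 1 gives a limit, > 32000 nM.
compound 2 `O=C1c2ccc(C#Cc3cccs3)nc2CCN1C1CCCC1` — in this assay compound 2 gives 2840 nM.
compound 3 `O=C1c2ccc(C#Cc3cccnc3)nc2CCN1C1CCCCC1` — in this assay compound 3 gives 15600 nM.

The value of compound 1 is a limit of the assay and not a number, so every step taken from it is a minimum (the limit of > 32000 nM in this assay, at which 1 of the 3 values shown sits).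

Two changes are covered. The first is thiophen-2-yl in place of pyridin-3-yl on a triple-bonded carbon. It made an at least 11-fold lower number from compound 1 to compound 2 (1.05 log units; beyond the scatter); the true size is not known since compound 1 sits at the limit (the limit of > 32000 nM in this assay, at which 1 of the 3 values shown sits). The second is the core difference, (cyclohexyl in place of cyclopentyl on an amide-type nitrogen in a ring). It made an at least 2.0-fold lower number from compound 1 to compound 3 (0.31 log units; beyond the scatter), again read against a limit.

Compound 4 `O=C1c2ccc(C#Cc3cccs3)nc2CCN1C1CCCCC1` is not yet measured. It differs from compound 3 by thiophen-2-yl in place of pyridin-3-yl on a triple-bonded carbon, the same change that separates compound 1 from compound 2, and at the same place. Compound 3 stands as the higher of the two numbers, with compound 2 the nearer one. On the core of compound 3 the step is expected to be a 10-fold lower number from compound 3 to compound 4 (1.02 log units; beyond the scatter), resting on the same change having made an at least 11-fold lower number from compound 1 to compound 2 (1.05 log units; beyond the scatter) and on compound 2 giving 2840 nM with the other core. Compound 4 is therefore estimated at 1500 nM in this assay, within 500 nM to 5000 nM.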

Compound 4, inhibition constant: 720 nM
Estimate against measurement, compound 4: 2.1-fold (0.32 log units) above; the measured number falls inside the stated range.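

In this assay, thiophen-2-yl in place of pyridin-3-yl on a triple-bonded carbon gives a 22-fold lower number from compound 3 to compound 4 (1.34 log units; beyond the scatter), so the change lowers the number on both cores shown and carries over in direction, with the step large on each: the same change on two cores in this assay, an at least 11-fold lower number (1.05 log units; beyond the scatter) from compound 1 to compound 2 and a 22-fold lower number (1.34 log units; beyond the scatter) from compound 3 to compound 4; the limit leaves it open whether they differ. Cyclohexyl in place of cyclopentyl on the amide-type nitrogen in a ring gives a 3.9-fold lower number from compound 2 to compound 4 (0.60 log units; beyond the scatter), and this second change also points the same way on both of the cores compared: the same change on two cores in this assay, an at least 2.0-fold lower number (0.31 log units; beyond the scatter) from compound 1 to compound 3 and a 3.9-fold lower number (0.60 log units; beyond the scatter) from compound 2 to compound 4; the limit leaves it open whether they differ. Compound 1 gives a limit and not a number, so neither step taken from it has a known size, and the notes cannot say whether either change is equal in size on the two cores or whether the two changes simply add: the limit of > 32000 nM in this assay, at which 1 of the 4 values shown sits.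

The compounds shown leave open whether phenyl or furan-2-yl on the triple-bonded carbon would behave as thiophen-2-yl does, and whether the trend from cyclopentyl to cyclohexyl continues to cycloheptyl or holds for an open chain such as tert-butyl on the amide-type nitrogen. Also open, from the compounds shown here alone, is how a hydroxyl or an amine on the cyclohexyl ring would shift the number in this assay.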